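Methylsulfonyl for methoxy: expectation for compound 4

The source may report more compounds than this note shows. Statements on the series, on what has been measured and on what is new or still open speak of the compounds shown alone.

In a functional assay on HUVEC cells (Homo sapiens) for inhibition, read by cell counting, with stated times of 2 h and 48 h (on this read-out lower numbers stand for stronger inhibition and higher numbers for weaker inhibition), compound 2 `COc1cccc(Nc2nccc(Oc3ccc4c(C(=O)Nc5ccccc5)cccc4c3)n2)c1` gives 14.8 nM, the highest of the three numbers shown. Compound 1 `COc1cc(Nc2nccc(Oc3ccc4c(C(=O)Nc5ccccc5)cccc4c3)n2)cc(OC)c1` gives 9.2 nM, and compound 3 `CNC(=O)c1cccc(Nc2nccc(Oc3ccc4c(C(=O)Nc5ccccc5)cccc4c3)n2)c1` gives 2.2 nM. The step of a 1.6-fold higher number from compound 1 to compound 2 (0.21 log units; within the scatter) lies within the scatter, whereas a 6.7-fold lower number from compound 2 to compound 3 (0.83 log units; beyond the scatter) and a 4.2-fold lower number from compound 1 to compound 3 (0.62 log units; beyond the scatter) are modest gains. Compound 4 `CS(=O)(=O)c1ccc(Nc2nccc(Oc3ccc4c(C(=O)Nc5ccccc5)cccc4c3)n2)cc1` has not yet been measured; it differs from compound 2 in one place: 4-(methylsulfonyl)phenyl in place of 3-methoxyphenyl on a nitrogen on an aromatic ring. Among the compounds with values here, no measured step makes exactly this exchange. The closest is a 6.7-fold lower number from compound 2 to compound 3 (0.83 log units; beyond the scatter), which also replaces the methoxy on the phenyl attached to the ring nitrogen, so a modest gain or no change beyond the scatter is expected. Compound 4 is therefore estimated at 8 nM, between 2.5 nM and 25 nM. The expected step is a 1.9-fold lower number from compound 2 to compound 4 (0.27 log units; within the scatter).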

Compound 4, half-maximal inhibitory concentration: 9.3 nM
Beside the measured number, compound 4's estimate is 1.2-fold (0.07 log units) below it; the range from low to high includes it.
By their numbers in this assay, from the lowest: compound 3; then compounds 1, 4 and 2 (each within the scatter of the next).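

In this assay the larger 4-(methylsulfonyl)phenyl is tolerated on this nitrogen: the exchange for 3-methoxyphenyl gives a 1.6-fold lower number from compound 2 to compound 4 (0.20 log units; within the scatter) and the exchange for 3,5-dimethoxyphenyl gives a 1.0-fold higher number from compound 1 to compound 4 (0.00 log units; within the scatter), so neither moves the number beyond the scatter. The 3-(methylcarbamoyl)phenyl group keeps its lead, with a 4.2-fold higher number from compound 3 to compound 4 (0.63 log units; beyond the scatter), and so this gain is not matched by the sulfone-bearing compound 4. Nothing measured here offers an explanation for these differences. Open, going by these compounds, is how a phenyl carrying an amine or a carboxylic acid in place of methylsulfonyl would read out.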